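From a fluorinated to a chlorinated aryl arm

A few compounds are considered here, and "the series" means these few. Any claim that something is new, unique, unknown or untested is made for them only; others in the source may bear on it.

Of the compounds shown here, three built on one shared core have been tested in an assay on HEK293 cells for binding affinity to prostaglandin E2 receptor EP1 subtype (Homo sapiens); on this read-out lower numbers stand for stronger inhibition and higher numbers for weaker inhibition. Compound 1 `O=C(O)CCCCCCN1C(=O)CC[C@@H]1CCC(O)Cc1ccccc1` is recorded only as a limit in this assay, at > 3200 nM. Compound 2 `O=C(O)c1ccc(CCCN2C(=O)CCC2CCC(O)Cc2ccc(F)cc2)cc1` likewise gives only a limit in this assay, > 3200 nM. Compound 3 `O=C(O)c1ccc(CCCN2C(=O)CC[C@@H]2CCC(O)Cc2ccc(Cl)cc2)s1` also sits at a limit in this assay, > 3200 nM. Among the measured compounds shown here, all three values therefore rest at the same point, (the limit of > 3200 nM in this assay, at which 3 of the 3 values shown sit), so no step between measured compounds can be read, and compound 2 stands level with the other two.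

Compound 4 `O=C(O)c1ccc(CCCN2C(=O)CCC2CCC(O)Cc2cccc(Cl)c2)cc1` differs from compound 2 in one place: 3-chlorophenyl in place of 4-fluorophenyl on a saturated chain carbon, two bonds along the chain from an oxygen on a saturated carbon. For the measured compounds named here, no measured pair shows what such a change does here, so the size of the step can only be guessed. Compound 2 is known only as a limit in this assay, > 3200 nM. The expectation is no step beyond the scatter, and compound 4 is estimated at 5000 nM, within 2000 nM to 20000 nM. The expected step reads a step that the limit leaves unreadable from compound 2 to compound 4.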

Compound 4, half-maximal inhibitory concentration: > 3200 nM
Compound 4: only a limit was reported (the forecaster's own chance of this, stated with the estimate: 75%); the middle value is on the limit's open side.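

In this assay compound 4 is recorded only as a limit (> 3200 nM). Compound 2 is also a limit there, so no step can be read between compound 2 and compound 4. The compounds shown leave open how strongly any of them inhibits and what 3-chlorophenyl in place of 4-fluorophenyl does here.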